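This account rests on a few compounds, and the source may have more. Where it says the series, first, only, none or still open, it means among the compounds named here.

Measured in a functional assay on the whole organism (strain albino) for inhibition, with Rattus norvegicus as the target, read by paw edema, with stated times of 1 h and 3 h, at a dose of 100 mg/kg by the oral route; on this read-out higher numbers stand for a stronger effect at the one dose given and lower numbers for a weaker effect:
compound 1 `N#Cc1c(Nc2ccc(O)cc2)nc(SCC(=O)Nn2c(COc3ccc(Cl)cc3Cl)nc3ccccc3c2=O)nc1-c1ccccc1` gives 59.7%
compound 2 `N#Cc1c(Nc2ccc(Cl)cc2)nc(SCC(=O)Nn2c(COc3ccc(Cl)cc3Cl)nc3ccccc3c2=O)nc1-c1ccc(Cl)cc1` gives 64.9%

Compound 2 has the higher of the two numbers, but compound 1 lies only a little below it and the gap is within the usual scatter of this assay, so the two cannot be placed in order. The two compounds differ in two places at once, so no single step can be read from them. Compound 3 `N#Cc1c(Nc2ccc(O)cc2)nc(SCC(=O)Nn2c(COc3ccc(Cl)cc3Cl)nc3ccccc3c2=O)nc1-c1ccc(Cl)cc1` is not yet measured. It departs from compound 2 by one change: hydroxy in place of chloro on an aromatic carbon. Because compound 2 gives 64.9% and compound 1, which carries the same hydroxy group on the same ring, gives 59.7%, no step beyond the scatter is expected for this change in this assay. The estimated step of a number 3.9 percentage points lower from compound 2 to compound 3 (within the scatter) is therefore small, in no firm direction. Compound 3 is expected to reach about 61%, within the range 50% to 72%.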

Compound 3, a percentage reported as inhibition, in the whole organism at one dose (the size of the read-out at that dose, not a potency): 91.2%
Beside the measured number, compound 3's estimate is 30.2 percentage points below it; the measured number lies above the stated range.
By their numbers in this assay, from the lowest: compounds 1 and 2 (each within the scatter of the next); then compound 3.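

In this assay, the (4-chlorophenyl)amino group gives way to (4-hydroxyphenyl)amino with a number 26.3 percentage points higher from compound 2 to compound 3 (beyond the scatter), so this position does respond to the change once the 4-chlorophenyl group is held fixed. The other single change, chloro in place of hydrogen on an aromatic carbon with the (4-hydroxyphenyl)amino group held fixed, gives a number 31.5 percentage points higher from compound 1 to compound 3 (beyond the scatter). Neither step could be read from the earlier pair, which differs in two places at once, and the highest number here belongs to the compound carrying both the hydroxy and the chloro group. Nothing shown here bears on what lies behind these rises. The compounds shown leave open whether a methoxy group or an amine in place of the hydroxy group would hold this number, and whether the chloro group could give way to fluoro.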